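The compounds below may be only part of what the source reports. "The series", "measured", "known", "first", "only" and "open" are said of these compounds alone.

Within the data shown here, in an assay on Vas deferens for inhibition of Adrenergic receptor alpha-1 (Rattus norvegicus), in the presence of a further agent that is not named here (on this read-out higher numbers stand for higher potency (the scale is a negative logarithm) and lower numbers for lower potency), compound 1 `CC(Oc1ccccc1)C1=NCCN1` gives 5.2, the lower of the two numbers measured so far. Compound 2 `CC(Oc1ccccc1Cc1ccccc1)C1=NCCN1` carries a benzyl in place of hydrogen on an aromatic carbon and gives 5.99. That change amounts to a number 0.79 log units higher from compound 1 to compound 2 (beyond the scatter). Compound 3 `CC(Oc1cccc(-c2ccccc2)c1)C1=NCCN1` differs from compound 1 by phenyl in place of hydrogen on an aromatic carbon. Among the measured compounds shown here, only the step from compound 1 to compound 2 bears on this; it came from a different group at a different carbon and was modest. A rise beyond the scatter is expected, estimated as a number 0.50 log units higher from compound 1 to compound 3 (beyond the scatter). Compound 3 is therefore expected to reach 5.7, between 5.1 and 6.3.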

Compound 3, negative logarithm of the half-maximal effective concentration: 4.53
The estimate for compound 3 lay 1.17 log units above the measured number; the whole stated range lies above it.
By their numbers in this assay, from the lowest: compound 3; then compound 1; then compound 2.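

At this carbon, meta to a group of 8 heavy atoms, phenyl in place of hydrogen gives a number 0.67 log units lower from compound 1 to compound 3 (beyond the scatter). Adding a six-membered aromatic ring to compound 1 therefore does not raise the number at every carbon, since benzyl at a different carbon gives a number 0.79 log units higher from compound 1 to compound 2 (beyond the scatter). No measurement shown here accounts for this opposite direction. Still open, from the compounds shown here alone, is whether a smaller group at this same carbon, such as methyl, methoxy or an amine, would also lower the number. Also open, going by these compounds, is what phenyl would do at the carbon that carries benzyl in compound 2.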